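Swapping an Aryl Ether for a Benzylamine on a Cell-Killing Core

A few compounds are considered here, and "the series" means these few. Any claim that something is new, unique, unknown or untested is made for them only; others in the source may bear on it.

Compound 1 `Nc1cc(N)c2nc(-c3ccccc3)c(Oc3ccc(Cl)c(Cl)c3)nc2c1` has been tested in a functional assay on 786-0 cells (Homo sapiens) for inhibition, read by sulforhodamine B assay, with a stated time of 48 h; a lower number here means that less compound is tolerated, a higher number that more compound is tolerated. In this test compound 1 reaches only a limit of the assay, < 100000 nM, not a number. A second measured compound, compound 2 `CCOC(=O)[C@H](CCC(=O)O)NC(=O)c1ccc(Sc2nc3cc(N)cc(N)c3nc2-c2ccccc2)cc1`, shares the same core but carries a very different side chain. In this assay compound 2 likewise gives only a limit, < 100000 nM. Both measured values sit at the limit of < 100000 nM in this assay, at which 2 of the 2 values shown sit, so nothing here separates the two compounds, and compound 1 cannot be placed above or below anything else on the numbers shown.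

Compound 3 `Nc1cc(N)c2nc(-c3ccccc3)c(NCc3ccc(F)cc3)nc2c1` has not yet been measured. It differs from compound 1 in one place: (4-fluorobenzyl)amino in place of 3,4-dichlorophenoxy on an aromatic carbon. Within the data shown here, no step between two measured compounds is known, so there is no measured change to lean on; the only guide is the pair of measured compounds, which offer no number at all. The step that the limit leaves unreadable from compound 1 to compound 3 is expected to be small, with no direction beyond the scatter. Compound 3 is estimated at 30000 nM in this assay, within 3000 nM to 100000 nM, and it may well again be reported only as a limit.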

Compound 3, concentration lethal to 50% of the cells: < 100000 nM
Compound 3: no number, only a limit (the forecaster's own chance of this, stated with the estimate: 60%); the middle value lies beyond the limit too.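

Compound 3 gives only a limit of the assay in this assay, < 100000 nM. The swap from compound 1 to compound 3 therefore cannot be read as a step: the limit of < 100000 nM in this assay, at which 3 of the 3 values shown sit.

The compounds shown leave open where each one truly lies and whether putting (4-fluorobenzyl)amino in place of 3,4-dichlorophenoxy changes cell killing at all.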